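This account rests on a few compounds, and the source may have more. Where it says the series, first, only, none or still open, it means among the compounds named here.

Within the data shown here, in a functional assay on L1210 cells (Mus musculus) for antiproliferative activity, read by cell counting, with a stated time of 2 days (on this read-out higher numbers stand for weaker inhibition and lower numbers for stronger inhibition), compound 1 (`COc1ccc(C(=O)c2sc(N3CCCC3)nc2N)cc1OC`) gives 60000 nM and is the only measured compound with an actual number. Compound 2 (`COc1ccc(C(=O)c2sc(N3CCCC3)nc2N)cc1`) stands at > 200000 nM which is a limit and not a number. Compound 3 (`COc1cccc(C(=O)c2sc(N3CCCC3)nc2N)c1`) also stands at a limit with > 200000 nM as its reading. Compound 2 therefore sits at the weak end of the series, at the limit of > 200000 nM in this assay, at which 2 of the 3 values shown sit, so far. Compound 4 (`Nc1nc(N2CCCC2)sc1C(=O)c1ccc(Cl)cc1`) differs from compound 2 by one change chloro in place of methoxy on an aromatic carbon in which chloro replaces methoxy on an aromatic carbon para to a large group. The nearest evidence comes from compound 1: hydrogen in place of methoxy gives an at least 3.3-fold higher number from compound 1 to compound 2 (0.52 log units; beyond the scatter) and the second such swap gives an at least 3.3-fold higher number from compound 1 to compound 3 (0.52 log units; beyond the scatter) as a loss of strength. Compound 4 has no methoxy either and neither step tests chloro, so no step beyond the scatter is expected in this assay for this swap. The estimated step is a number no higher from compound 2 to compound 4 (the limit leaves the size open) and another reading at the limit is quite possible. The estimated value for compound 4 is 200000 nM within an expected range of 70000 nM to 400000 nM at this stage.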

Compound 4, half-maximal inhibitory concentration: > 200000 nM
Compound 4 ended at the assay's limit (the forecaster's own chance of this, stated with the estimate: 70%); the middle value lies on the limit itself.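

Among these compounds, compound 2 and compound 4 both end at a limit of this assay rather than at a number, so no step between them can be read. The compounds shown leave open whether chloro in place of methoxy changes antiproliferative strength at all.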